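The source may report more compounds than this note shows. Statements on the series, on what has been measured and on what is new or still open speak of the compounds shown alone.

Compound 2, whose structure is `Cc1ccc(C2=NN(c3nc(-c4ccc(Br)cc4)cs3)C(c3ccc(F)cc3)C2)s1`, belongs to a small set of three close analogues that were all tested for their effect on the growth of mouse fibroblast cells. In an ADME assay on NIH3T3 cells (Mus musculus) for cytotoxicity, read by XTT assay, with a stated time of 24 h (a lower number here means a stronger inhibitor, a higher number a weaker inhibitor), compound 2 gives > 500 ug/mL, and this is a limit of the assay rather than a number. Compound 1, with the structure `Cc1ccc(C2=NN(c3nc(-c4ccccc4)cs3)C(c3ccc(F)cc3)C2)s1`, gives > 500 ug/mL in this assay, also a limit. Compound 3, with the structure `Fc1ccc(C2CC(c3ccc(Cl)s3)=NN2c2nc(-c3ccc(Br)cc3)cs2)cc1`, gives > 500 ug/mL in this assay, again a limit. Going by the values given here, the whole measured set therefore sits at one place, namely (the limit of > 500 ug/mL in this assay, at which 3 of the 3 values shown sit), so no compound can be set above or below another.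

Two single changes connect these compounds. The step that the two limits leave unreadable from compound 1 to compound 2 cannot be read, since both ends are limits. The step that the two limits leave unreadable from compound 2 to compound 3 is unreadable for the same reason.

Compound 4, with the structure `Cc1ccc(C2=NN(c3nc(-c4ccc(Cl)cc4)cs3)C(c3ccc(F)cc3)C2)s1`, has not yet been measured. It differs from compound 2 in one place: chloro in place of bromo on an aromatic carbon. Neither measured step gives a readable size, so the expected step of a number no higher from compound 2 to compound 4 (the limit leaves the size open) is none beyond the scatter, with compound 4 most likely ending at the same limit. The estimate for compound 4 in this assay is 500 ug/mL, within a range from 200 ug/mL to 1000 ug/mL.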

Compound 4, half-maximal inhibitory concentration: > 500 ug/mL
Compound 4 ended at the assay's limit; the forecaster's own chance of this, stated with the estimate: 85%; the middle value sits exactly at the limit.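

Going by these compounds alone, no step to compound 4 from compound 1 or compound 2 can be read, as the whole set stands at one limit: the limit of > 500 ug/mL in this assay, at which 4 of the 4 values shown sit. The compounds shown leave open how strongly any of them acts in this assay, and whether hydrogen, chloro or bromo on the six-membered aromatic ring makes any difference there.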